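The source may report more compounds than this note shows. Statements on the series, on what has been measured and on what is new or still open speak of the compounds shown alone.

Compound 1 `O=C(CCc1ccccc1)NCc1ccc2[nH]c(=O)c(-c3nccs3)c(CCc3ccccc3)c2c1` belongs to a small set of two measured compounds that share the same core. In an ADME assay on microsomes from liver (Homo sapiens) for metabolic stability, with a stated time of 0.5 h (on this read-out higher numbers stand for a more stable compound and lower numbers for a less stable compound), compound 1 gives 3%, the lowest of the two numbers in hand. The other measured compound, compound 2 `O=C(COc1ccc2[nH]c(=O)c(-c3nccs3)c(CCc3ccccc3)c2c1)NC1(c2ccccc2)CC1`, differs from compound 1 in more than one place, and in this assay compound 2 gives 46%, a gap above compound 1 that lies beyond the usual scatter of repeated measurements.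

Compound 3 `CC(C)(NC(=O)NCc1ccc2[nH]c(=O)c(-c3nccs3)c(CCc3ccccc3)c2c1)c1ccccc1` has not yet been measured. It departs from compound 1 in a single place: (1-methyl-1-phenylethyl)amino in place of phenethyl on a carbonyl carbon. Going by the values given here, no measured pair shows this exact change, so the expectation for compound 3 rests on the position of compound 1 and on the change itself. A modest rise in this assay is expected, a step from compound 1 to compound 3 of a number 12 percentage points higher from compound 1 to compound 3 (beyond the scatter). For compound 3 in this assay the estimate is 15%, within a range from 3% to 40%.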

Compound 3, percent of the compound remaining: 40%
Compound 3: the middle estimate sits 25 percentage points below what was measured; low and high end bracket the measured number.
By their numbers in this assay, from the lowest: compound 1; then compounds 3 and 2 (each within the scatter of the next).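

Swapping one group on the carbonyl carbon is enough to change the result strongly in this assay: with (1-methyl-1-phenylethyl)amino in place of phenethyl, the step reads a number 37 percentage points higher from compound 1 to compound 3 (beyond the scatter) and counts as large. Going by these compounds alone, until now the two measured compounds differed in more than one place, so this is the first shift that can be tied to a single change, one in which the six-membered aromatic ring stays while a nitrogen with its hydrogen-bond donor enters. No measurement at hand explains the rise.

Still open, on these data alone, is which part of the entering group goes with the rise, the nitrogen or the two methyl groups. A phenethylamino group or a simple methylamino group on the same carbonyl carbon would help to separate these parts.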